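This account rests on a few compounds, and the source may have more. Where it says the series, first, only, none or still open, it means among the compounds named here.

Measured so far in an ADME assay on SH-SY5Y cells (Homo sapiens) for cytotoxicity, read by MTT assay, with a stated time of 24 h, tested at 25 uM; on this read-out lower numbers stand for a stronger effect and higher numbers for a weaker effect at the one concentration tested:
compound 1, `COc1cc2c(cc1O)CCC(C)(CC(=O)O)O2`: 92.5%
compound 2, `COc1cc2c(cc1O)CCC(C)(CCNC(=O)/C=C(C)/C=C/C=C(C)/C=C/C1=C(C)CCCC1(C)C)O2`: 91.2%

Compound 1 holds the highest of the two numbers. Its nearest neighbour is compound 2, whose reading lies lower by an amount that stays within the usual scatter of this assay, so the two compounds cannot be separated on this read-out; both sit near the weak end of the effect scale. Among the compounds with values here, no two measured compounds differ from each other in a single place, so no measured step is available to lean on.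

Compound 3, `COc1cc2c(cc1O)CCC(C)(CCNC(C)=O)O2`, has not yet been measured in this assay. Against compound 1 the change is acetamidomethyl in place of carboxy on a saturated chain carbon bound to a saturated ring carbon. The rest of the shared core is untouched.

Within the data shown here, with no measured step and two measured compounds that agree within the scatter, no step beyond the scatter is expected for this change in this assay: the estimated step is a number 2.5 percentage points lower from compound 1 to compound 3 (within the scatter). Compound 3 is expected to give 90%, with a range from 78% to 100%.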

Compound 3, a percentage reported as activity, at one concentration (the size of the read-out at that concentration, not a potency): 76.2%
The estimate for compound 3 lay 13.8 percentage points above the measured number; the measured number lies below the stated range.
By their numbers in this assay, from the lowest: compound 3; then compounds 2 and 1 (each within the scatter of the next).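

In this assay, within the data shown here, acetamidomethyl in place of carboxy on a saturated chain carbon bound to a saturated ring carbon gives a number 16.3 percentage points lower from compound 1 to compound 3 (beyond the scatter), the first step that can be told from the scatter, and it shows that the read-out at this position responds to the group carried there, moving towards the stronger effect. This holds for this one change and is no rule for amides, as compound 2, which also carries an amide on this chain, gives 91.2%. The data shown offer no measurement that accounts for the step.

Among these compounds, the one step changes the group and the chain length together, so it remains open whether the lower reading follows the amide or the longer chain, and how a primary amine or a methyl ester on the same chain would read in this assay. With readings at a single concentration, the step gives the size of the effect there and leaves open how compound 3 would behave at other concentrations.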